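The compounds below may be only part of what the source reports. "The series", "measured", "known", "first", "only" and "open" are said of these compounds alone.

Compound 3 `COc1cc(C(=O)N2CCN(C(=O)c3cc(OC)c(OC)c(OC)c3)C(COC(=O)NCCC(C)C)C2)cc(OC)c1OC` gives 140 nM in a functional assay (Oryctolagus cuniculus) for inhibition of platelet-activating factor receptor (Cavia porcellus) (a lower number here means a stronger inhibitor, a higher number a weaker inhibitor), the lowest of the two carbamate numbers, with compound 2 `CCCCNC(=O)OCC1CN(C(=O)c2cc(OC)c(OC)c(OC)c2)CCN1C(=O)c1cc(OC)c(OC)c(OC)c1` nearest at 240 nM. The ester compound 1 `COc1cc(C(=O)N2CCN(C(=O)c3cc(OC)c(OC)c(OC)c3)C(COC(=O)C(C)(C)C)C2)cc(OC)c1OC` gives 100 nM; 100 nM; 120 nM (3 entries) in this assay, and its repeat entries the several entries of compound 1 in this assay, 100 nM; 100 nM; 120 nM (3 entries) show how closely values of this kind recur. Compound 4 `CCC(C)CNC(=O)OCC1CN(C(=O)c2cc(OC)c(OC)c(OC)c2)CCN1C(=O)c1cc(OC)c(OC)c(OC)c1` differs from compound 3 by sec-butyl in place of isobutyl on a saturated chain carbon bound to an amide-type nitrogen. Within the data shown here, the only measured step on this side chain, a 1.7-fold lower number from compound 2 to compound 3 (0.23 log units; within the scatter), is a change within the chain that stayed inside the scatter. The move from isobutyl to sec-butyl keeps the same atoms, so no step beyond the scatter is expected, no change at the digits printed from compound 3 to compound 4 (within the scatter). Compound 4 is therefore estimated at 140 nM in this assay, within a range of 70 nM to 280 nM.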

Compound 4, half-maximal inhibitory concentration: 470 nM
The estimate for compound 4 lay 3.4-fold (0.53 log units) below the measured number, and the stated range ends below it.
By their numbers in this assay, from the lowest: compounds 3, 2 and 4 (each within the scatter of the next, the first and the last beyond it).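

With the same atoms, a 3.4-fold higher number from compound 3 to compound 4 (0.53 log units; beyond the scatter), so in this assay the arrangement of the branch on this chain can register beyond the scatter. Methyl in place of hydrogen on the butyl chain gives a 1.7-fold lower number from compound 2 to compound 3 (0.23 log units; within the scatter), and at the other chain carbon a 2.0-fold higher number from compound 2 to compound 4 (0.29 log units; within the scatter); each step is small alone, yet the two products separate. Repeat values of this kind recur closely: the several entries of compound 1 in this assay, 100 nM; 100 nM; 120 nM (3 entries)

From the compounds shown here alone, whether a longer chain, a cyclohexylmethyl group or a terminal amine on this carbamate would keep or lose the number remains open.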